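This account rests on a few compounds, and the source may have more. Where it says the series, first, only, none or still open, it means among the compounds named here.

Compound 1 `CC(=O)Oc1ccc(-c2ccc(F)cc2F)cc1C(=O)Nc1ccccc1`, compound 2 `CC(=O)Oc1ccc(-c2ccc(F)cc2F)cc1C(=O)Nc1ccc(C)cc1` and compound 3 `O=C(Oc1ccc(-c2ccc(F)cc2F)cc1C(=O)Nc1ccccc1)c1ccccc1` were all tested in a functional assay on the whole organism (Ear) for inhibition, with Mus musculus as the target, at a dose of 40 mg/kg by the oral route; a higher number here means more inhibition at the dose given (going by the name of the read-out), a lower number less inhibition. In this assay compound 1 gives 23.2%, compound 2 gives 36.4% and compound 3 gives 19.8%. Compound 2 differs from compound 1 in one place (methyl in place of hydrogen on an aromatic carbon), and this change gave a number 13.2 percentage points higher from compound 1 to compound 2 (beyond the scatter). The core of compound 3 differs from that of compound 1 by phenyl in place of methyl on a carbonyl carbon, a step of a number 3.4 percentage points lower from compound 1 to compound 3 (within the scatter). Compound 4 `Cc1ccccc1NC(=O)c1cc(-c2ccc(F)cc2F)ccc1OC(=O)c1ccccc1` has not yet been measured; it differs from compound 3 by methyl in place of hydrogen on an aromatic carbon. Among the compounds with values here, this is the same kind of change as the one from compound 1 to compound 2, but the methyl now sits ortho to a large group rather than para to a large group. A gain is expected here as well, though a smaller one; that rests on the step of a number 13.2 percentage points higher from compound 1 to compound 2 (beyond the scatter) and on the place of the methyl not being the same. In this assay compound 4 is expected to give 27%, most likely between 13% and 41%. The expected step is a number 7.2 percentage points higher from compound 3 to compound 4 (within the scatter).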

Compound 4, a percentage reported as inhibition, in the whole organism at one dose (the size of the read-out at that dose, not a potency): 21.4%
For compound 4 the middle estimate is 5.6 percentage points above the measured one, within the range that was stated.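

On the core of compound 3, methyl in place of hydrogen gave a number 1.6 percentage points higher from compound 3 to compound 4 (within the scatter) in this assay, so no clear gain can be read from this step alone. Set beside the earlier step, the two do not clearly differ: the same change on two cores in this assay, a number 13.2 percentage points higher (beyond the scatter) from compound 1 to compound 2 and a number 1.6 percentage points higher (within the scatter) from compound 3 to compound 4, 11.6 percentage points apart, within the scatter of two such steps. This does not show that the gain carries over, nor that it is lost; the methyl in compound 4 also sits ortho to a large group, unlike in compound 2, so core and place change together and their shares cannot be separated.

The compounds shown leave open how a methyl at one fixed place behaves on both cores. They also leave open what a chlorine atom, a methoxy group or an amine would do in place of that methyl.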